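The source may report more compounds than this note shows. Statements on the series, on what has been measured and on what is new or still open speak of the compounds shown alone.

Working notes on the series, all in a functional assay on HeLa cells (Homo sapiens) for cytotoxicity, read by MTT assay; a higher number here means a weaker inhibitor, a lower number a stronger inhibitor. Compound 1 (`CC(C)=CC[C@@H](OC(=O)CCO)C1=CC(=O)c2c(O)ccc(O)c2C1=O`) gives 67600 nM, compound 2 (`CC(C)=CC[C@@H](OC(=O)C1CCOC1)C1=CC(=O)c2c(O)ccc(O)c2C1=O`) gives 73500 nM, and compound 3 (`CC(C)=CC[C@@H](OC(=O)CC(C)(O)C(C)C)C1=CC(=O)c2c(O)ccc(O)c2C1=O`) gives 27700 nM, the lowest number of the three. Compound 1 and compound 2 do not separate: a 1.1-fold higher number from compound 1 to compound 2 (0.04 log units; within the scatter). Compound 3 stands apart from both, with a 2.4-fold lower number from compound 1 to compound 3 (0.39 log units; beyond the scatter) and a 2.7-fold lower number from compound 2 to compound 3 (0.42 log units; beyond the scatter), both modest but beyond the scatter.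

The next entry is compound 4 (`CC(C)=CC[C@@H](OCCO)C1=CC(=O)c2c(O)ccc(O)c2C1=O`). Its difference from compound 3 is 2-hydroxyethyl in place of (2-hydroxy-2,3-dimethylbutyl)carbonyl on an oxygen on a saturated carbon. In words, 2-hydroxyethyl comes in place of (2-hydroxy-2,3-dimethylbutyl)carbonyl on an oxygen on a saturated carbon. Among the measured compounds shown here, no measured step removes the carbonyl from this oxygen, so that part of the change is untested. The nearest guide is the pair of steps into compound 3, a 2.4-fold lower number from compound 1 to compound 3 (0.39 log units; beyond the scatter) and a 2.7-fold lower number from compound 2 to compound 3 (0.42 log units; beyond the scatter). Compound 4 gives up the branched chain that those steps brought in, so a step of similar modest size, in the opposite direction, is expected. A move to a higher number is therefore expected: a 2.1-fold higher number from compound 3 to compound 4 (0.32 log units; beyond the scatter). For compound 4 the estimated value is 58000 nM, with an expected range of 22000 nM to 130000 nM, kept wide for the untested loss of the carbonyl.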

Compound 4, half-maximal inhibitory concentration: 18600 nM
The estimate for compound 4 lay 3.1-fold (0.49 log units) above the measured number; measured number outside the range, below it.
By their numbers in this assay, from the lowest: compounds 4 and 3 (each within the scatter of the next); then compounds 1 and 2 (each within the scatter of the next).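

Among the compounds shown here, with 2-hydroxyethyl in place of (2-hydroxy-2,3-dimethylbutyl)carbonyl on this oxygen, compound 3 and compound 4 do not separate in this assay (a 1.5-fold lower number from compound 3 to compound 4 (0.17 log units; within the scatter)), so the branched acyl chain of compound 3 is not the only group at this position that reaches this level. The clearest reading of the carbonyl itself comes from 2-hydroxyethyl in place of (2-hydroxyethyl)carbonyl (a 3.6-fold lower number from compound 1 to compound 4 (0.56 log units; beyond the scatter)), and the replacement of (oxolan-3-yl)carbonyl points the same way (a 4.0-fold lower number from compound 2 to compound 4 (0.60 log units; beyond the scatter)), so at this oxygen the carbonyl is dispensable and, with these two acyl groups, its absence goes with a modestly lower number. Nothing available on these compounds speaks to the reason for this behaviour.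

A plain ethyl on this oxygen would show whether the hydroxyl of the 2-hydroxyethyl group matters, and a longer chain or an amine at the chain end would show how much room for change this position has. From the compounds shown here alone, all of these readings come from this assay alone, so whether the same order holds in other cells remains open.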